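Aryloxyacetamide series: adding a methyl to compound 2

The compounds below may be only part of what the source reports. "The series", "measured", "known", "first", "only" and "open" are said of these compounds alone.

Measured compounds:
compound 1, `Cc1ccccc1OCC(=O)Nc1ccc(OCC(=O)O)c(F)c1`: 20.8%
compound 2, `CC(C)c1cccc(OCC(=O)Nc2ccc(OCC(=O)O)c(F)c2)c1`: 43.3%
compound 3, `O=C(O)COc1ccc(NC(=O)COc2cccc(C(F)(F)F)c2)cc1F`: 11.4%

In a functional assay on CHO cells for agonist activity at Free fatty acid receptor 1 (Homo sapiens), read by FLIPR, tested at 100 nM (on this read-out higher numbers stand for a stronger effect at the one concentration tested and lower numbers for a weaker effect), compound 2 gives the highest of the three numbers; compound 1 lies next, compound 3 furthest, and both gaps fall beyond the scatter. Within the data shown here, the single one-place step recorded within the set is a number 31.9 percentage points lower from compound 2 to compound 3 (beyond the scatter), so exchanging the isopropyl for a trifluoromethyl costs much of the signal.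

Compound 4, `Cc1ccc(C(C)C)cc1OCC(=O)Nc1ccc(OCC(=O)O)c(F)c1`, is not yet measured. It differs from compound 2 as follows: methyl in place of hydrogen on an aromatic carbon. Among the measured compounds shown here, no measured step concerns a methyl entering an aromatic position, so the step from compound 2 to compound 3 bears on compound 4 only indirectly: it shows that the group para to the new methyl matters, and compound 4 keeps that isopropyl. Compound 1 carries a methyl at the comparable ring position but lacks the isopropyl; its value against compound 2 shows only what the two numbers show, as the two structures differ in more than one place.

The expected step is therefore modest, likely within or close to the scatter: a number 1.7 percentage points higher from compound 2 to compound 4 (within the scatter). For compound 4 the estimated value in this assay is 45%, with a range from 25% to 65%.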

Compound 4, a percentage reported as activity, at one concentration (the size of the read-out at that concentration, not a potency): 14.6%
For compound 4 the middle estimate is 30.4 percentage points above the measured one; the whole stated range lies above it.
By their numbers in this assay, from the lowest: compounds 3, 4 and 1 (each within the scatter of the next); then compound 2.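

In this assay, a methyl on this aromatic carbon, ortho to a large group and para to an isopropyl group, is far from a silent change: the result is a number 28.7 percentage points lower from compound 2 to compound 4 (beyond the scatter), so this position, which carries hydrogen in compound 2, is sensitive to even a single added carbon. The second step, a number 6.2 percentage points lower from compound 1 to compound 4 (within the scatter), shows that with the methyl in place the isopropyl brings no readable gain, so in these compounds the benefit seen with the isopropyl in compound 2 appears only when this carbon carries hydrogen, and the two groups do not simply add up. The data hold no measurement that accounts for either step.

From the compounds shown here alone, it remains open whether a fluorine, a chlorine or a methoxy on the same carbon would read like the methyl of compound 4 or like the hydrogen of compound 2. Among these compounds, a reading at one concentration also shows only that compound 4 has a weaker effect than compound 2 at that concentration, and leaves open how the two compare at any other concentration.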